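Compound 3: replacing the 2H-indazol-2-yl group

This account rests on a few compounds, and the source may have more. Where it says the series, first, only, none or still open, it means among the compounds named here.

In an ADME assay on the whole organism (strain Wistar-Han) for pharmacokinetics, with Rattus norvegicus as the target, at a dose of 5 mg/kg by the oral route (on this read-out higher numbers stand for higher oral bioavailability and lower numbers for lower oral bioavailability), compound 1 (`CCC[C@H](c1ccc(C(=O)NCCC(=O)O)cc1)[C@H](c1ccc(Cl)cc1)c1c[nH]c2c(F)cc(C)cc12`) gives 7% and compound 2 (`CCCC(Oc1ccc(-n2cc3ccccc3n2)cc1)c1ccc(C(=O)NCCC(=O)O)cc1`) gives 3%. These two numbers lie within the scatter of each other, so compound 2 stands level with compound 1. Compound 3 (`CCCC(Oc1ccc(-n2cc(C(F)(F)F)cn2)cc1)c1ccc(C(=O)NCCC(=O)O)cc1`) carries 4-(trifluoromethyl)-1H-pyrazol-1-yl in place of 2H-indazol-2-yl on an aromatic carbon. Within the data shown here, no measured pair differs in one place, and the data offer no direct guide to this change. The expected step, a number 5 percentage points higher from compound 2 to compound 3 (within the scatter), is small, upward and within the scatter. For compound 3 the estimate is 8%, with an expected range of 2% to 25%.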

Compound 3, oral bioavailability: 60%
Compound 3: the middle estimate sits 52 percentage points below what was measured; the whole stated range lies below it.
By their numbers in this assay, from the lowest: compounds 2 and 1 (each within the scatter of the next); then compound 3.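

In this assay, the aromatic carbon para to a large group proves highly sensitive: 4-(trifluoromethyl)-1H-pyrazol-1-yl in place of 2H-indazol-2-yl gives a number 57 percentage points higher from compound 2 to compound 3 (beyond the scatter). This is the series' first single-place step, and it comes with no change in hydrogen-bond donors or acceptors. Nothing available accounts for the size of this step.

On these data alone, the step removes the six-membered aromatic ring and adds trifluoromethyl together, so their separate shares stay open. As far as these compounds go, how a nitrile or a methyl in place of the trifluoromethyl would read also remains unknown.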